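Changing the group on the sulfonamide nitrogen

A few compounds are considered here, and "the series" means these few. Any claim that something is new, unique, unknown or untested is made for them only; others in the source may bear on it.

In a functional assay on DU-145 cells (Homo sapiens) for antiproliferative activity, read by sulforhodamine B assay, with a stated time of 72 h (on this read-out higher numbers stand for weaker inhibition and lower numbers for stronger inhibition), compound 1 (`Cc1cc(C)nc(NS(=O)(=O)c2ccc(Nc3nncc4ccccc34)cc2)n1`) gives 7.8 nM. Compound 3 (`Clc1ccc(C(/C=C/c2ccccc2)=N\Nc2nncc3ccccc23)cc1`) gives 4.6 nM, within the scatter of compound 1. Compound 2 (`C(=C/c1ccccc1)\C(=N\Nc1nncc2ccccc12)c1ccccc1`) gives 1.3 nM, a lower number than compound 1 and beyond the scatter of it.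

Compound 4 (`O=S(=O)(Nc1ccccn1)c1ccc(Nc2nncc3ccccc23)cc1`) carries pyridin-2-yl in place of 4,6-dimethylpyrimidin-2-yl on a sulfonamide nitrogen.

Going by the values given here, no measured step changes this group, and compound 1 is the only measured compound with a sulfonamide nitrogen. Among the compounds with values here, the one measured step, a 3.5-fold higher number from compound 2 to compound 3 (0.55 log units; beyond the scatter), is chloro in place of hydrogen on an aromatic carbon. It is modest and bears only indirectly, as a guide to the size of a single change within the series. With no direct evidence for a direction, the expected result is a 1.2-fold higher number from compound 1 to compound 4 (0.06 log units; within the scatter), with no change beyond the scatter expected. For compound 4 the estimate is 9 nM, with an expected range of 3 nM to 30 nM.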

Compound 4, half-maximal inhibitory concentration: 54 nM
For compound 4 the middle estimate is 6.0-fold (0.78 log units) below the measured one, outside the stated range (above it).
By their numbers in this assay, from the lowest: compound 2; then compounds 3 and 1 (each within the scatter of the next); then compound 4.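

The group on the sulfonamide nitrogen is a position that responds to change: in this assay, pyridin-2-yl in place of 4,6-dimethylpyrimidin-2-yl gives a 6.9-fold higher number from compound 1 to compound 4 (0.84 log units; beyond the scatter), so this exchange weakens inhibition beyond the scatter. The exchange alters more than one feature at once, going from 8 heavy atoms and 2 hydrogen-bond acceptors in the group that leaves to 6 and 1 in the group that enters. Nothing available explains the shift in this read-out.

The compounds shown leave open whether the shift follows the second ring nitrogen or the two methyl groups, a separation that unsubstituted pyrimidin-2-yl or 4,6-dimethylpyridin-2-yl would address. Also open, as far as these compounds go, is how a non-aromatic group on this nitrogen, such as an acetyl or a morpholine-bearing chain, would read.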